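The compounds below may be only part of what the source reports. "The series", "measured", "known", "first", "only" and "open" are said of these compounds alone.

Compound 1 `CCCC(=O)Nc1ccn([C@@H]2CO[C@H](CO)O2)c(=O)n1`: 6600 nM
Compound 2 `O=C(Nc1ccn([C@@H]2CO[C@H](CO)O2)c(=O)n1)C1CCCCC1`: 7370 nM
Compound 3 `O=C(Nc1ccn([C@@H]2CO[C@H](CO)O2)c(=O)n1)c1ccc(F)cc1`: 8670 nM

In a functional assay on A549 cells (Homo sapiens) for cytotoxicity, read by sulforhodamine B assay, with a stated time of 72 h (a higher number here means a weaker inhibitor, a lower number a stronger inhibitor), compound 1 has the lowest of the three numbers, but the other two sit close: a 1.1-fold higher number from compound 1 to compound 2 (0.05 log units; within the scatter), a 1.3-fold higher number from compound 1 to compound 3 (0.12 log units; within the scatter), and a 1.2-fold higher number from compound 2 to compound 3 (0.07 log units; within the scatter). None of these changes on the carbonyl carbon moved the number beyond the scatter.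

Compound 4 `O=C(Nc1ccn([C@@H]2CO[C@H](CO)O2)c(=O)n1)c1ccc(Br)cc1` differs from compound 1 by 4-bromophenyl in place of propyl on a carbonyl carbon. Among the compounds with values here, the steps that bear on this are the two from compound 1, both within the scatter, with compound 3 the closest analogue in kind. No step beyond the scatter is therefore expected in this assay.

Compound 4 is estimated at 8000 nM, with a range of 4000 nM to 16000 nM. This corresponds to an expected step of a 1.2-fold higher number from compound 1 to compound 4 (0.08 log units; within the scatter).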

Compound 4, half-maximal inhibitory concentration: 4530 nM
Beside the measured number, compound 4's estimate is 1.8-fold (0.25 log units) above it; low and high end bracket the measured number.
By their numbers in this assay, from the lowest: compounds 4, 1, 2 and 3 (each within the scatter of the next).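

The exchange of fluoro for bromo on an aromatic carbon gives a 1.9-fold lower number from compound 3 to compound 4 (0.28 log units; within the scatter) in this assay and is the first change shown on the aromatic ring itself. On the carbonyl carbon, 4-bromophenyl gives a 1.5-fold lower number from compound 1 to compound 4 (0.16 log units; within the scatter) and a 1.6-fold lower number from compound 2 to compound 4 (0.21 log units; within the scatter) so propyl, cyclohexyl, 4-fluorophenyl and 4-bromophenyl remain indistinguishable in this assay. No available evidence bears on the reason for these results.

The compounds shown leave open whether an amine or a carboxylic acid on the aromatic ring would move the number beyond the scatter. As far as these compounds go, a much longer chain on the carbonyl carbon also remains open.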